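The compounds below may be only part of what the source reports. "The series", "measured", "known", "first", "only" and "open" are said of these compounds alone.

- Compound 1 `CN1CCN(C(=S)SCc2ccc3nc(N)nc(N)c3c2)CC1`: 9200 nM
- Compound 2 `Nc1nc(N)c2cc(CSC(=S)N3CCN(c4ccc(F)cc4F)CC3)ccc2n1`: 5120 nM
- Compound 3 `Nc1nc(N)c2cc(CSC(=S)N3CCN(c4ccccn4)CC3)ccc2n1`: not yet measured

Within the data shown here, in a functional assay on A549 cells (Homo sapiens) for antiproliferative activity, read by MTT assay, with a stated time of 72 h (on this read-out lower numbers stand for stronger inhibition and higher numbers for weaker inhibition), compound 2, at 5120 nM, stands level with compound 1, the only other compound measured so far. Compound 3 differs from compound 2 by pyridin-2-yl in place of 2,4-difluorophenyl on an amine nitrogen in a ring; in short, pyridin-2-yl in place of 2,4-difluorophenyl on an amine nitrogen in a ring. Among the measured compounds shown here, one measured step bears on this place: a 1.8-fold lower number from compound 1 to compound 2 (0.25 log units; within the scatter). Even that exchange of methyl for 2,4-difluorophenyl stayed within the scatter, so no change beyond the scatter is expected in this assay. The expected step is a 1.3-fold higher number from compound 2 to compound 3 (0.10 log units; within the scatter). For compound 3 the estimated value is 6500 nM, with an expected range of 2500 nM to 16000 nM.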

Compound 3, half-maximal inhibitory concentration: 3960 nM
Compound 3: middle estimate off by 1.6-fold (0.22 log units), on the high side; low and high end bracket the measured number.
By their numbers in this assay, from the lowest: compounds 3, 2 and 1 (each within the scatter of the next, the first and the last beyond it).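

In this assay, the exchange of 2,4-difluorophenyl for pyridin-2-yl gives a 1.3-fold lower number from compound 2 to compound 3 (0.11 log units; within the scatter) and so does not separate these two aromatic rings on the amine nitrogen. Among these compounds, replacing methyl with pyridin-2-yl at the same place gives a 2.3-fold lower number from compound 1 to compound 3 (0.37 log units; beyond the scatter) and is the only step here that clears the scatter, though only modestly. No measurement shown explains this difference. Still open, from the compounds shown here alone, is whether a plain phenyl, a benzyl or an acetyl on this nitrogen would read like methyl or like pyridin-2-yl.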